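One Small Chain Swap in a Cytotoxic Series

The source may report more compounds than this note shows. Statements on the series, on what has been measured and on what is new or still open speak of the compounds shown alone.

Among the compounds with values here, only two compounds have numbers so far in a functional assay on P388 cells (Mus musculus) for cytotoxicity; on this read-out higher numbers stand for weaker inhibition and lower numbers for stronger inhibition. There, compound 1 (`COc1ccc(C[C@H]2C(=O)N[C@@H](C)C(=O)N(C)[C@H]3Cc4ccc(cc4)Oc4cc(ccc4OC)C[C@@H](C(=O)N[C@H](C)C(=O)N[C@@H](CSC(C)=O)C(=O)N2C)N(C)C3=O)cc1`) gives 9.77 nM. Compound 2 (`CCCN1C(=O)[C@@H](C)NC(=O)[C@@H]2Cc3ccc(OC)c(c3)Oc3ccc(cc3)C[C@@H](C(=O)N2C)N(C)C(=O)[C@H](C)NC(=O)[C@H](Cc2ccc(OC)cc2)N(C)C(=O)[C@@H]1C`) gives 3.98 nM, the lower of the two numbers, and the gap between them lies beyond the usual scatter of repeated measurements.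

Compound 3 (`C=C(C)CN1C(=O)[C@@H](C)NC(=O)[C@@H]2Cc3ccc(OC)c(c3)Oc3ccc(cc3)C[C@@H](C(=O)N2C)N(C)C(=O)[C@H](C)NC(=O)[C@H](Cc2ccc(OC)cc2)N(C)C(=O)[C@@H]1C`) has not yet been measured. It keeps the core of compound 2 and alters one chain, with 1-methylethenyl in place of ethyl on a saturated chain carbon bound to an amide-type nitrogen in a ring. Cut one bond further out, this is propyl becoming 2-methylprop-2-en-1-yl.

Within the data shown here, no pair of measured compounds differs in just one place, so no measured step can guide this forecast. The natural starting point is compound 2 at 3.98 nM. In this assay, I expect no step beyond the scatter, and neither direction is favoured by the data. The estimated step is a 1.3-fold higher number from compound 2 to compound 3 (0.10 log units; within the scatter). For compound 3, the expected value is 5 nM, with an estimated range from 2 nM to 12 nM.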

Compound 3, half-maximal inhibitory concentration: 11 nM
For compound 3 the middle estimate is 2.2-fold (0.34 log units) below the measured one; the range from low to high includes it.
By their numbers in this assay, from the lowest: compound 2; then compounds 1 and 3 (each within the scatter of the next).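

In this assay this position on the shared core proves sensitive to the chain it carries: placing 1-methylethenyl in place of ethyl, on a saturated chain carbon bound to an amide-type nitrogen in a ring, gives a 2.8-fold higher number from compound 2 to compound 3 (0.44 log units; beyond the scatter) and so moves the number towards weaker inhibition. Within the data shown here, this is the first step that can be read at a single place, and it shows that swapping one short carbon chain for another is enough to move the value beyond the scatter, although compound 3 at 11 nM still acts in the nanomolar range. Nothing available on these compounds accounts for the shift.

As far as these compounds go, this single step cannot separate the double bond from the branching, so it remains open which of the two goes with the higher number. The compounds shown also leave open how a longer straight chain, a benzyl group or a chain ending in an amine would read at this place.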